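The source may report more compounds than this note shows. Statements on the series, on what has been measured and on what is new or still open speak of the compounds shown alone.

Among the compounds with values here, compound 2, `Fc1ccc2ccn(CCCCN3CCN(C(c4ccccc4)c4ccccc4)CC3)c2c1`, is the only compound that has a number in an assay on RPMI-8226 cells for antagonist activity at P2X purinoceptor 7 (Homo sapiens), read by calcium flux; a higher number here means a weaker inhibitor, a lower number a stronger inhibitor: compound 2 gives 110 nM. Compound 1, `COc1ccc2c(ccn2CCCCN2CCN(C(c3ccccc3)c3ccccc3)CC2)c1`, is the other measured compound, and in this assay compound 1 reaches only a limit, > 10000 nM. That limit is the one described in the limit of > 10000 nM in this assay, at which 1 of the 2 values shown sits. Within the data shown here, the single measured step, an at least 90-fold lower number from compound 1 to compound 2 (1.95 log units; beyond the scatter), is the whole of the evidence on what the group on the saturated chain carbon, four bonds along the chain from an amine nitrogen in a ring, does to the readout. Compound 3, `c1ccc(-c2nnnn2CCCCN2CCN(C(c3ccccc3)c3ccccc3)CC2)cc1`, differs from compound 2 by 5-phenyl-1H-tetrazol-1-yl in place of 6-fluoro-1H-indol-1-yl on a saturated chain carbon, four bonds along the chain from an amine nitrogen in a ring. The measured step bears on this change only in that it concerns the same place; the group entering in compound 3 resembles neither of the two already seen, so the direction is not secured. Because an at least 90-fold lower number from compound 1 to compound 2 (1.95 log units; beyond the scatter) was large, a large step is expected here too, and the estimate leans toward a weaker inhibitor: the expected step is a 14-fold higher number from compound 2 to compound 3 (1.13 log units; beyond the scatter). Compound 3 is thus estimated at 1500 nM, within 150 nM to 10000 nM.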

Compound 3, half-maximal inhibitory concentration: 3200 nM
The estimate for compound 3 lay 2.1-fold (0.33 log units) below the measured number; the measured number falls inside the stated range.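

With a third group at the same place, on a saturated chain carbon, four bonds along the chain from an amine nitrogen in a ring, the range of the readout in this assay becomes clearer: 5-phenyl-1H-tetrazol-1-yl in place of 6-fluoro-1H-indol-1-yl gives a 29-fold higher number from compound 2 to compound 3 (1.46 log units; beyond the scatter), leaving compound 2 the strongest inhibitor of the three. Set against 5-methoxy-1H-indol-1-yl, the same group gives an at least 3.1-fold lower number from compound 1 to compound 3 (0.49 log units; beyond the scatter), so compound 3 falls between the two compounds with indolyl groups, and carrying an indolyl group at this place does not by itself secure the stronger readout. This second step has only a lower bound, as compound 1 reaches only a limit: the limit of > 10000 nM in this assay, at which 1 of the 3 values shown sits.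

Left open is what an unsubstituted 1H-indol-1-yl, a 5-fluoro-1H-indol-1-yl or a 6-methoxy-1H-indol-1-yl group would give here, so the identity of the fluorine or methoxy group cannot be separated from where it sits. From the compounds shown here alone, what a shorter or longer chain would do also stays open, the chain and the rest of the core being the same in all three compounds.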